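The source may report more compounds than this note shows. Statements on the series, on what has been measured and on what is new or still open speak of the compounds shown alone.

Of the compounds shown here, three built on one shared core have been tested in a functional assay on LoVo cells (Homo sapiens) for inhibition, read by MTT assay, with a stated time of 24 h; a lower number here means a stronger inhibitor, a higher number a weaker inhibitor. Compound 1 `CC1(C)[C@H]2CC[C@]1(C)N(Cc1cn(-c3ccccc3C#N)nn1)C(=O)C2` gives 140 nM, compound 2 `CC1(C)[C@H]2CC[C@]1(C)N(Cc1cn(-c3cccc(C#N)c3)nn1)C(=O)C2` gives 320 nM, and compound 3 `CC1(C)[C@H]2CC[C@]1(C)N(Cc1cn(-c3cccc(Cl)c3)nn1)C(=O)C2` gives 70 nM. Compound 2 therefore carries the highest number of the three, since a 2.3-fold higher number from compound 1 to compound 2 (0.36 log units; beyond the scatter) and a 4.6-fold lower number from compound 2 to compound 3 (0.66 log units; beyond the scatter) both lie beyond the scatter. The unmeasured compound 4 `Cc1ccc(-n2cc(CN3C(=O)C[C@@H]4CC[C@@]3(C)C4(C)C)nn2)cc1` differs from compound 2 in one place: 4-methylphenyl in place of 3-cyanophenyl on an aromatic nitrogen. The closest guide is the step with chloro in place of cyano, where a 4.6-fold lower number from compound 2 to compound 3 (0.66 log units; beyond the scatter); in compound 4 the nitrile likewise disappears, though 4-methylphenyl rather than 3-chlorophenyl takes the place. A step in the same direction, somewhat smaller, is expected: a 2.1-fold lower number from compound 2 to compound 4 (0.33 log units; beyond the scatter). Compound 4 is estimated to give about 150 nM, within a range from 60 nM to 400 nM.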

Compound 4, half-maximal inhibitory concentration: 50 nM
Beside the measured number, compound 4's estimate is 3.0-fold (0.48 log units) above it, outside the stated range (below it).
By their numbers in this assay, from the lowest: compounds 4, 3 and 1 (each within the scatter of the next, the first and the last beyond it); then compound 2.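

Putting 4-methylphenyl in place of 3-cyanophenyl on the aromatic nitrogen gives a 6.4-fold lower number from compound 2 to compound 4 (0.81 log units; beyond the scatter) and shows that this position keeps a low number with a group that has no nitrile and no hydrogen-bond acceptor. The other two comparisons place compound 4 among the better compounds: a 1.4-fold lower number from compound 3 to compound 4 (0.15 log units; within the scatter) leaves it level with the 3-chlorophenyl compound, while a 2.8-fold lower number from compound 1 to compound 4 (0.45 log units; beyond the scatter) separates it from the 2-cyanophenyl compound. No measured evidence here explains these differences.
Still open, going by these compounds, is how an amine or a carboxylic acid on the phenyl ring, or a longer chain in place of the methyl, would read in this assay.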